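This account rests on a few compounds, and the source may have more. Where it says the series, first, only, none or still open, it means among the compounds named here.

Compound 1 `CC(O)(CSc1cccc(OC(F)(F)F)c1)C(=O)Nc1cc(C(F)(F)F)cc(C(F)(F)F)c1`, compound 2 `CC(O)(CSc1ccccc1OC(F)(F)F)C(=O)Nc1cc(C(F)(F)F)cc(C(F)(F)F)c1`, compound 3 `CC(O)(CS(=O)(=O)c1cccc(OC(F)(F)F)c1)C(=O)Nc1cc(C(F)(F)F)cc(C(F)(F)F)c1` and compound 4 `CC(O)(CS(=O)(=O)c1ccccc1OC(F)(F)F)C(=O)Nc1cc(C(F)(F)F)cc(C(F)(F)F)c1` share one core and are set apart by the arylthio or arylsulfonyl arm and by where the trifluoromethoxy group sits on its ring. In a functional assay on DU-145 cells (Homo sapiens) for antiproliferative activity, read by fluorescence and propidium iodide staining, with a stated time of 96 h (a lower number here means a stronger inhibitor, a higher number a weaker inhibitor), compound 1 gives 9610 nM and compound 2 gives 6410 nM. The change between them is 2-(trifluoromethoxy)phenyl in place of 3-(trifluoromethoxy)phenyl on a sulfur, and it made a step of a 1.5-fold lower number from compound 1 to compound 2 (0.18 log units; within the scatter). Compound 3 gives 14100 nM in this assay; this is the highest of the three numbers, within the scatter of compound 1 but beyond the scatter of compound 2. How the core of compound 3 differs from the core of compound 1 is not broken down here. Compound 4 is not yet measured; it differs from compound 3 by 2-(trifluoromethoxy)phenyl in place of 3-(trifluoromethoxy)phenyl on a sulfonyl sulfur. This is the same kind of change as that from compound 1 to compound 2, though the place is a sulfonyl sulfur here rather than a sulfur, in both cases with a saturated chain carbon as the other neighbour. Because the earlier step of a 1.5-fold lower number from compound 1 to compound 2 (0.18 log units; within the scatter) stayed within the scatter, the step for compound 4 is expected to be about a 1.4-fold lower number from compound 3 to compound 4 (0.15 log units; within the scatter) in this assay. Compound 4 is therefore estimated at 10000 nM, between 5000 nM and 22000 nM.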

Compound 4, half-maximal inhibitory concentration: 12900 nM
Compound 4: the middle estimate sits 1.3-fold (0.11 log units) below what was measured, within the range that was stated.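

In this assay, 2-(trifluoromethoxy)phenyl in place of 3-(trifluoromethoxy)phenyl on a sulfonyl sulfur gave a 1.1-fold lower number from compound 3 to compound 4 (0.04 log units; within the scatter), so on this core too the swap leaves the number where the scatter alone could put it. Set beside the earlier step on the core with a plain sulfur, the change reads the same on both cores, with no difference that can be told apart: the same change on two cores in this assay, a 1.5-fold lower number (0.18 log units; within the scatter) from compound 1 to compound 2 and a 1.1-fold lower number (0.04 log units; within the scatter) from compound 3 to compound 4, 1.4-fold (0.14 log units) apart, within the scatter of two such steps What this supports is narrow: across this one pair of cores and in this one assay, the swap carried over as a step too small to read, but since neither step stands clear of the scatter, it does not show that a real effect of fixed size or direction travels from one core to the other, nor that the same would hold on any further core.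

The compounds shown leave open whether the trifluoromethoxy group could be exchanged for a methoxy, a nitrile or a carboxylic acid with an equally small step on either core. They also leave open what a sulfinyl link on the sulfur, or an amine in place of the hydroxyl on the shared core, would do to the number.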